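A few compounds are considered here, and "the series" means these few. Any claim that something is new, unique, unknown or untested is made for them only; others in the source may bear on it.

Measured compounds:
- Compound 1 `COc1cc(C)cc(-c2c(-c3ccnc(-c4ccc(C(C)=O)cc4)c3)cnn2CC#N)c1`: 91%
- Compound 2 `Cc1cc(O)cc(-c2nn(CC#N)cc2-c2ccnc(-c3ccc(Oc4ccccc4)cc3)c2)c1`: 94%
- Compound 3 `COc1cc(C)cc(-c2nn(CC#N)cc2-c2ccnc(-c3ccc(N(C)C)cc3)c2)c1`: 97%

All three compounds share a core and were tested in a functional assay on HCT-116 cells (Homo sapiens) for cytotoxicity, read by sulforhodamine B assay, with a stated time of 48 h, tested at 0.01 uM; a higher number here means a weaker effect of the compound at the concentration tested, a lower number a stronger effect. Compound 3 gives the highest of the three numbers, but its nearest neighbour compound 2 lies close enough that the gap falls within the usual scatter, and the same holds for the gap to compound 1, so no order can be read among them; at this concentration all three leave the cells almost untouched.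

The step to compound 4 `Cc1cc(O)cc(-c2nn(CC#N)cc2-c2ccnc(-c3ccc(N(C)C)cc3)c2)c1` changes one place: hydrogen in place of methyl on an oxygen on an aromatic ring. Compound 2 already carries the hydroxy group on its 3-hydroxy-5-methylphenyl ring, paired with a different far group, and its number sits close to that of compound 3. Among the compounds with values here, no pair of measured compounds shows exactly this exchange, so the size of the step is open, but nothing among the measured numbers points to a move beyond the scatter in this assay. For compound 4, a step of a number 2 percentage points lower from compound 3 to compound 4 (within the scatter) is expected, which is no change beyond the scatter. Compound 4 is therefore estimated at 95%, with a range from 85% to 100%.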

Compound 4, a percentage reported as activity, at one concentration (the size of the read-out at that concentration, not a potency): 98%
The estimate for compound 4 lay 3 percentage points below the measured number; the range from low to high includes it.
By their numbers in this assay, from the lowest: compounds 1, 2, 3 and 4 (each within the scatter of the next).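

In this assay, the exchange of methoxy for hydroxy on the aromatic ring can now be read directly, with the far group held constant: it gives a number 1 percentage points higher from compound 3 to compound 4 (within the scatter) and so leaves the read-out unchanged at this concentration. The far group can also be read in a single step, as dimethylamino in place of phenoxy gives a number 4 percentage points higher from compound 2 to compound 4 (within the scatter) with the hydroxy group held constant, so neither change separates these compounds here. Nothing measured on these compounds offers an explanation for either result.

With a single low concentration, the compounds shown leave open whether the methoxy-to-hydroxy exchange would matter at a concentration where the cells are clearly affected. Also open, as far as these compounds go, is what an amine or a longer ethoxy chain would do in the place of the hydroxy group.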